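A few compounds are considered here, and "the series" means these few. Any claim that something is new, unique, unknown or untested is made for them only; others in the source may bear on it.

In an assay on isolated protein for displacement of a labelled ligand from metabotropic glutamate receptor 5 (Homo sapiens), with a stated time of 60 min, tested at 1 uM (on this read-out lower numbers stand for less inhibition and higher numbers for more inhibition at the one concentration tested (going by the name of the read-out)), the measured compounds read:
compound 1 `Cc1ccc(S(=O)(=O)c2cnc3ccc(Cl)cc3c2N2CCC(C)CC2)cc1F`: 68%
compound 2 `Cc1ccc2ncc(S(=O)(=O)c3cc(Cl)cc(Cl)c3)c(N3CCC(C)CC3)c2c1`: 75%
compound 3 `Cc1cc(C)cc(S(=O)(=O)c2cnc3ccc(C)cc3c2N2CCC(C)CC2)c1`: 80%

Of the three numbers, that of compound 1 is the smallest; it differs from compound 2 within the scatter and from compound 3 beyond it. Compound 4 `Cc1ccc(S(=O)(=O)c2cnc3ccc(Cl)cc3c2N2CCC(C)CC2)cc1` follows from compound 1 by hydrogen in place of fluoro on an aromatic carbon. Within the data shown here, the one measured step, a number 5 percentage points higher from compound 2 to compound 3 (within the scatter), changes the same aryl group on the sulfonyl sulfur but swaps different substituents, and no measured step removes a fluoro; it bears only loosely on this change. A step no larger than the scatter is therefore expected, with no clear direction, namely no change at the digits printed from compound 1 to compound 4 (within the scatter). Compound 4 is estimated at 68%, between 50% and 84%.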

Compound 4, a percentage reported as inhibition, at one concentration (the size of the read-out at that concentration, not a potency): 95%
Compound 4: middle estimate off by 27 percentage points, on the low side, outside the stated range (above it).
By their numbers in this assay, from the lowest: compounds 1, 2 and 3 (each within the scatter of the next, the first and the last beyond it); then compound 4.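

Hydrogen in place of fluoro, on the aromatic carbon ortho to a methyl group, gives a number 27 percentage points higher from compound 1 to compound 4 (beyond the scatter) in this assay. Among these compounds, the read-out therefore responds to a single heavy atom at this position, whereas the one earlier step on the aryl group on the sulfonyl sulfur stayed within the scatter. Nothing measured here accounts for the size of this step.

Going by these compounds, whether chloro, methoxy or an amine at this position would read closer to compound 1 or compound 4 remains open. So does whether the step holds with other groups on the shared core.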